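Compound 3 to compound 4: stepping from a limit

The compounds below may be only part of what the source reports. "The series", "measured", "known", "first", "only" and "open" are said of these compounds alone.

Compound 1 `COC(=O)CC/C(C)=C/Cc1c(OC)c(C)c2c(c1OCC#CCN1CCN(c3ccc(C#N)cc3)CC1)C(=O)OC2` in a functional assay on HT-29 cells (Homo sapiens) for inhibition, read by sulforhodamine B assay (on this read-out lower numbers stand for stronger inhibition and higher numbers for weaker inhibition), gives > 50000 nM as a limit
Compound 2 `COC(=O)CC/C(C)=C/Cc1c(OC)c(C)c2c(c1OCC#CCN1CCN(c3ccccc3OC)CC1)C(=O)OC2` in this assay gives > 50000 nM as a limit
Compound 3 `COC(=O)CC/C(C)=C/Cc1c(OC)c(C)c2c(c1OCC#CCN1CCCc3ccccc31)C(=O)OC2` in this assay gives > 50000 nM as a limit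

Compound 3 stands at > 50000 nM in this assay as a limit and not a number. Among the compounds with values here, the other two compounds are also limits, so the series shows the limit of > 50000 nM in this assay, at which 3 of the 3 values shown sit, and no readable number so far.

The change to compound 4 `COC(=O)CC/C(C)=C/Cc1c(OC)c(C)c2c(c1OCC#CCN1CCC(C(=O)OC)CC1)C(=O)OC2` is 4-(methoxycarbonyl)piperidin-1-yl in place of 1,2,3,4-tetrahydroquinolin-1-yl on a saturated chain carbon bound to a triple-bonded carbon and amounts to 4-(methoxycarbonyl)piperidin-1-yl in place of 1,2,3,4-tetrahydroquinolin-1-yl on a saturated chain carbon bound to a triple-bonded carbon.

Within the data shown here, the only measured step is a step that the two limits leave unreadable from compound 1 to compound 2 and it lends no size to this change. The expectation therefore rests on compound 3 at > 50000 nM as a limit. No step beyond the scatter is expected in either direction, and the estimated step is an at least 1.1-fold lower number from compound 3 to compound 4 (0.04 log units; that floor lies within the scatter) in this assay terms. For compound 4 the estimated value is 45000 nM with an expected range from 15000 nM to 50000 nM in this assay terms, most likely reported again as a limit.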

Compound 4, half-maximal inhibitory concentration: > 50000 nM
Compound 4: only a limit was reported; the forecaster's own chance of this, stated with the estimate: 75%; middle value at least 1.1-fold (0.04 log units) from the limit.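

Compound 3 and compound 4 both stand as limits, so no step between them can be read, and the series stays at a single limit: the limit of > 50000 nM in this assay, at which 4 of the 4 values shown sit.

The compounds shown leave open how far apart their true values lie and which change to the shared core would give a readable number.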